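The source may report more compounds than this note shows. Statements on the series, on what has been measured and on what is new or still open speak of the compounds shown alone.

Compound 1 `Fc1ccc(-c2cn3ccnc3c(-c3ccc4ncn(C5CCCCC5)c4c3)n2)cc1`, compound 2 `CC(=O)c1ccc(-c2cn3ccnc3c(-c3ccc4ncn(C5CCCCC5)c4c3)n2)cc1` and compound 3 `Fc1ccccc1-c1cn2ccnc2c(-c2ccc3ncn(C4CCCCC4)c3c2)n1` share one core and differ only in the aromatic group attached to it. In a functional assay on NCI-H460 cells (Homo sapiens) for inhibition, read by sulforhodamine B assay, with a stated time of 48 h, tested at 10 uM (a lower number here means less inhibition, a higher number more inhibition at the concentration tested (going by the name of the read-out)), compound 1 gives 6.12%, compound 2 gives 7.12% and compound 3 gives 8.1%. Compound 3 stands at the top of these three numbers, but only by small margins: the step of a number 2 percentage points higher from compound 1 to compound 3 (within the scatter) and the step of a number 1 percentage points higher from compound 2 to compound 3 (within the scatter) both fall within the usual scatter, so the three compounds cannot be told apart on these data.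

Compound 4 `c1csc(-c2cn3ccnc3c(-c3ccc4ncn(C5CCCCC5)c4c3)n2)c1` is built from compound 3 by a change at the same position: thiophen-2-yl in place of 2-fluorophenyl on an aromatic carbon. For the measured compounds named here, no measured step exchanges a six-membered aromatic group for a five-membered one, so the closest guides are the two steps above, in which swapping one aromatic group for another at this place moved the read-out by amounts within the scatter. Compound 4 is therefore expected to give an inhibition about 7%, with a range from 0% to 20%, and the expected step of a number 1.1 percentage points lower from compound 3 to compound 4 (within the scatter) is none beyond the scatter.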

Compound 4, a percentage reported as inhibition, at one concentration (the size of the read-out at that concentration, not a potency): 1.3%
Estimate against measurement, compound 4: 5.7 percentage points above; low and high end bracket the measured number.
By their numbers in this assay, from the lowest: compounds 4, 1, 2 and 3 (each within the scatter of the next).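

In this assay a five-membered aromatic ring with sulfur replaces a six-membered carbon ring at this position, a bigger change of ring type than the swaps between phenyl groups, yet the steps of a number 6.8 percentage points lower from compound 3 to compound 4 (within the scatter) and a number 5.8 percentage points lower from compound 2 to compound 4 (within the scatter) and a number 4.8 percentage points lower from compound 1 to compound 4 (within the scatter) all stay within the usual variation between repeats. With thiophen-2-yl or any of the three substituted phenyl groups at this position, the numbers show no difference that these data can resolve, and the four compounds cannot be ranked. Nothing available here explains the result or links it to a property of either group.

As far as these compounds go, it remains open whether an amine or a carboxylic acid on a longer chain at this position would shift the inhibition beyond that variation. From the compounds shown here alone, the effect of replacing the cyclohexyl group on the shared core is also open.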